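The source may hold more compounds than are shown below. What is called first, only, known or untested is meant among the compounds shown, and "the series" means these compounds.

The series shares one core, seen in compound 1 `Cc1cc(-c2nc3cc(F)c(F)cc3s2)ccc1N`, compound 2 `Nc1ccc(-c2nc3cc(F)ccc3s2)cc1I` and compound 3 `Nc1ccc(-c2nc3ccc(F)cc3s2)cc1Cl`, and each was tested in a functional assay on cells (Cancer cell lines, Homo sapiens) for inhibition; a lower number here means a stronger inhibitor of growth, a higher number a weaker inhibitor of growth. Compound 1 returns only a limit of the assay, < 10 nM. Compound 3 likewise returns only a limit, < 10 nM. Among the compounds with values here, compound 2 is the one member that gives a number, 70 nM, so it alone can be placed on the scale; the other two sit at the limit of < 10 nM in this assay, at which 2 of the 3 values shown sit, and what separates them from compound 2 beyond that cannot be read from these figures.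

The step under consideration goes from compound 2 to compound 4 `Nc1ccc(-c2nc3cc(F)ccc3s2)cc1`, which has not yet been measured in this assay. The change is hydrogen in place of iodo on an aromatic carbon.

Within the data shown here, no step between two measured compounds is available, so the direction of this one is taken from the standing of compound 2 alone. With compound 2 already giving a number where compound 1 and compound 3 give only limits, the expectation is that removing the iodo group will leave compound 4 no stronger, and more likely somewhat weaker, with an expected step of a 2.1-fold higher number from compound 2 to compound 4 (0.33 log units; beyond the scatter). The estimate for compound 4 in this assay is therefore 150 nM, expected to fall between 30 nM and 800 nM.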

Compound 4, concentration for 50% growth inhibition: 11500 nM
Beside the measured number, compound 4's estimate is 77-fold (1.88 log units) below it, outside the stated range (above it).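

Taking the iodo group off this aromatic carbon, ortho to an amino group, is far from a minor edit: this assay records a 160-fold higher number from compound 2 to compound 4 (2.22 log units; beyond the scatter). Within the data shown here, this is the first direct reading of what one substituent at this place contributes, and it shows that, with the rest of compound 2 unchanged, hydrogen there leaves compound 4 a much weaker inhibitor of growth. The figures give the size of this step but not its origin, and nothing measured here bears on why iodo and hydrogen differ so widely.

From the compounds shown here alone, it remains open whether this large step is particular to iodo or whether a bromo, methoxy, nitrile or trifluoromethyl group at the same carbon would hold the strength of compound 2 in this assay. The chloro and methyl groups of compound 3 and compound 1 leave this unsettled: both compounds differ from compound 4 in more than one place, and both return only limits of the assay.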